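Benzyl ring variation on a shared pyrazole amide core

The source may report more compounds than this note shows. Statements on the series, on what has been measured and on what is new or still open speak of the compounds shown alone.

Compounds measured in an assay on Sf21 cells for inhibition of high affinity nerve growth factor receptor (Homo sapiens), read by HTRF, with a stated time of 30 min, in the presence of a further agent that is not named here; a lower number here means a stronger inhibitor, a higher number a weaker inhibitor:
compound 1, `CC1(C)c2[nH]nc(NC(=O)c3ccccc3)c2CN1Cc1cccc(C#N)c1`, gives 980 nM
compound 2, `CC1(C)c2[nH]nc(NC(=O)c3ccccc3)c2CN1Cc1cccc(I)c1`, gives 1360 nM
compound 3, `CC1(C)c2[nH]nc(NC(=O)c3ccccc3)c2CN1Cc1ccccc1F`, gives 450 nM

Compound 2 carries the highest number of the three. Its nearest neighbour is compound 1, where the step of a 1.4-fold higher number from compound 1 to compound 2 (0.14 log units; within the scatter) lies within the scatter; the step of a 3.0-fold lower number from compound 2 to compound 3 (0.48 log units; beyond the scatter) is the largest gap shown. Compound 4, `CC1(C)c2[nH]nc(NC(=O)c3ccccc3)c2CN1Cc1ccc(F)cc1`, differs from compound 2 as follows: 4-fluorophenyl in place of 3-iodophenyl on a saturated chain carbon bound to an amine nitrogen in a ring.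

Within the data shown here, no measured step pairs a 3-iodophenyl with a 4-fluorophenyl. Among the measured compounds shown here, the steps that bear on it are a 3.0-fold lower number from compound 2 to compound 3 (0.48 log units; beyond the scatter) and a 2.2-fold lower number from compound 1 to compound 3 (0.34 log units; beyond the scatter), both modest, both toward a lower number when a fluorophenyl replaces the substituted phenyl of compound 1 or compound 2; the fluorine in compound 3 sits elsewhere on its ring than in compound 4, so the transfer is uncertain. On that basis compound 4 is expected to show a modest step of a 1.7-fold lower number from compound 2 to compound 4 (0.23 log units; within the scatter) toward a lower number, with a chance of no step beyond the scatter. The estimate for compound 4 is 800 nM, ranging from 300 nM to 2000 nM.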

Compound 4, half-maximal inhibitory concentration: 1180 nM
Compound 4: middle estimate off by 1.5-fold (0.17 log units), on the low side; measured number inside the range.
By their numbers in this assay, from the lowest: compound 3; then compounds 1, 4 and 2 (each within the scatter of the next).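

In this assay, this saturated chain carbon bound to an amine nitrogen in a ring shows a difference between two fluorophenyl groups: a 2.6-fold higher number from compound 3 to compound 4 (0.42 log units; beyond the scatter) is a modest step with only the name of the fluorophenyl changed. Fluorine on the phenyl therefore does not by itself set the number, since a 1.2-fold lower number from compound 2 to compound 4 (0.06 log units; within the scatter) and a 1.2-fold higher number from compound 1 to compound 4 (0.08 log units; within the scatter) both leave compound 4 level with the 3-iodophenyl and 3-cyanophenyl compounds, and of the four compounds only compound 3 stands apart. Nothing available gives a reason for the gap between the two fluorophenyl groups.

The compounds shown leave open whether the lower number of compound 3 belongs to fluorine alone or would also come with a chlorine or a methoxy group on the ring. They also leave open what an unsubstituted benzyl or a longer chain carrying an amine would give on the shared core.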